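The compounds below may be only part of what the source reports. "The series", "measured", "known", "first", "only" and "open" are said of these compounds alone.

Working notes on the series in a functional assay on HeLa cells (Homo sapiens) for cytotoxicity, read by MTT assay, with a stated time of 48 h; a lower number here means a stronger inhibitor, a higher number a weaker inhibitor. Compound 1 (`COc1ccc(-c2nc3ccccn3c2C(=O)/C=C\Nc2ccc3[nH]ccc3c2)cc1`) gives 13600 nM, compound 2 (`COc1ccc(-c2nc3ccccn3c2C(=O)/C=C\Nc2ccc3cc[nH]c3c2)cc1`) gives 15300 nM and compound 3 (`COc1ccc(-c2nc3ccccn3c2C(=O)/C=C\Nc2cnc3ccccc3c2)cc1`) gives 9440 nM. Compound 3 stands level with the other two, as the steps are all small: a 1.4-fold lower number from compound 1 to compound 3 (0.16 log units; within the scatter) and a 1.6-fold lower number from compound 2 to compound 3 (0.21 log units; within the scatter). The remaining step is a 1.1-fold higher number from compound 1 to compound 2 (0.05 log units; within the scatter).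

Compound 4 (`O=C(/C=C\Nc1cnc2ccccc2c1)c1c(-c2ccc(Cl)cc2)nc2ccccn12`) keeps the quinolin-3-yl of compound 3 on the amine nitrogen, but has chloro in place of methoxy on an aromatic carbon, the change from 4-methoxyphenyl to 4-chlorophenyl: chloro in place of methoxy on an aromatic carbon.

All three measured steps exchange the group on the amine nitrogen, and all three measured compounds carry methoxy. For the measured compounds named here, none of these steps therefore tests the new change directly, and the series holds no measured chloro compound. With so little evidence, no shift beyond the scatter is expected, and the estimated step is a 1.0-fold lower number from compound 3 to compound 4 (0.02 log units; within the scatter). The estimate for compound 4 is 9000 nM, with an expected range from 4000 nM to 20000 nM.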

Compound 4, half-maximal inhibitory concentration: 3720 nM
Compound 4: the middle estimate sits 2.4-fold (0.38 log units) above what was measured, and the stated range ends above it.
By their numbers in this assay, from the lowest: compound 4; then compounds 3, 1 and 2 (each within the scatter of the next).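

For the compounds shown here, the position on the aromatic carbon, left unchanged by the earlier steps, does affect the read-out: in this assay, chloro in place of methoxy gives a 2.5-fold lower number from compound 3 to compound 4 (0.40 log units; beyond the scatter) and is the only step beyond the scatter. The exchanges on the amine nitrogen all stay within the scatter, which leaves the change from 4-methoxyphenyl to 4-chlorophenyl as the one clear shift, although it rests on a single pair carrying quinolin-3-yl. No measurement shown gives a reason for this shift.

On these data alone, whether the same change holds with 1H-indol-5-yl or 1H-indol-6-yl on the amine nitrogen remains open. Also open, as far as these compounds go, is how fluoro, bromo, methyl or trifluoromethyl would compare with chloro at this place.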